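This account rests on a few compounds, and the source may have more. Where it says the series, first, only, none or still open, it means among the compounds named here.

Compound 1 has the structure `C=CC1=C(C(=O)NCCC)C(c2ccc(OC)c(OC)c2)OC1`. In a functional assay on SW480 cells (Homo sapiens) for cytotoxicity, read by MTT assay, with a stated time of 24 h (on this read-out higher numbers stand for weaker inhibition and lower numbers for stronger inhibition), compound 1 gives only a limit, > 100000 nM.
Compound 2 has the structure `C=CC1=C(C(=O)NCc2ccc(C)cc2)C(c2ccc(OC)c(OC)c2)OC1`. In this assay compound 2 gives only a limit, > 100000 nM.
Compound 3 has the structure `C=CC1=C(C(=O)NCc2ccc(Cl)cc2)C(c2ccc(OC)c(OC)c2)OC1`. In this assay compound 3 gives only a limit, > 100000 nM.

The three measured compounds share one core and differ only in the group carried on the amide nitrogen. Compound 3 stands exactly where the other two stand, at the limit of the assay and not at a number: the limit of > 100000 nM in this assay, at which 3 of the 3 values shown sit. Compound 4, `C=CC1=C(C(=O)O)C(c2ccc(OC)c(OC)c2)OC1`, differs from compound 3 in one place: hydroxy in place of (4-chlorobenzyl)amino on a carbonyl carbon. The steps measured so far swap the group on the amide nitrogen or a substituent on its ring, and none of them can be read, since both ends sit at the limit: a step that the two limits leave unreadable from compound 1 to compound 2, a step that the two limits leave unreadable from compound 1 to compound 3, a step that the two limits leave unreadable from compound 2 to compound 3. Going by the values given here, none of them removes the whole amine part and leaves a hydroxy on the carbonyl carbon, so no measured step speaks to the change that leads to compound 4. With every value at the limit, there is no number from which a direction could be taken.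

Compound 4 is therefore expected to sit, like the rest, at or near the limit, around 100000 nM with a range of 30000 nM to 300000 nM in this assay. That amounts to an expected step of a number no higher from compound 3 to compound 4 (the limit leaves the size open), none beyond the scatter.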

Compound 4, half-maximal inhibitory concentration: > 100000 nM
Compound 4: a limit, no number (the forecaster's own chance of this, stated with the estimate: 85%); the middle value lies on the limit itself.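

Compound 4 gives only a limit, as do compound 1, compound 2 and compound 3, so no step from those three to compound 4 can be read: the limit of > 100000 nM in this assay, at which 4 of the 4 values shown sit.

The compounds shown leave open whether any group on the carbonyl carbon of the shared core gives a measurable value on this read-out.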